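Hydroxy in place of bromo in compound 2

The compounds below may be only part of what the source reports. "The series", "measured", "known", "first", "only" and "open" are said of these compounds alone.

Three closely related compounds have been measured in a functional assay on HT-1080 cells (Homo sapiens) for cytotoxicity, read by MTT assay, with a stated time of 72 h; a lower number here means a stronger inhibitor, a higher number a weaker inhibitor. Compound 1 `COc1cccc(/C=C2\CCC/C(=C\c3ccc(Cl)cc3)C2=O)c1OC` gives 11100 nM, compound 2 `COc1cccc(/C=C2\CCC/C(=C\c3ccc(Br)cc3)C2=O)c1OC` gives 13700 nM, and compound 3 `COc1cccc(/C=C2\CCC/C(=C\c3cccc(OC)c3OC)C2=O)c1` gives 9900 nM. Compound 2 therefore stands within the scatter of both others, and these numbers give it no rank among them.

The next compound is compound 4 `COc1cccc(/C=C2\CCC/C(=C\c3ccc(O)cc3)C2=O)c1OC`, which differs from compound 2 as follows: hydroxy in place of bromo on an aromatic carbon. The change is made on an aromatic carbon, para to a large group.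

Among the measured compounds shown here, three measured steps bear on this change. The closest is a 1.2-fold higher number from compound 1 to compound 2 (0.09 log units; within the scatter), which exchanges bromo for chloro at the same place. Two wider steps replace the whole halogenated aryl group with 3-methoxyphenyl: a 1.1-fold lower number from compound 1 to compound 3 (0.05 log units; within the scatter) and a 1.4-fold lower number from compound 2 to compound 3 (0.14 log units; within the scatter). All three remain within the scatter, but none of them introduces a hydroxy group, so the data do not directly show the effect of this substitution. On this limited evidence, no step beyond the scatter is expected in this assay, and no direction is firmly indicated.

The expected result is a 1.4-fold lower number from compound 2 to compound 4 (0.14 log units; within the scatter). For compound 4 the estimate is 10000 nM, with an expected range from 4000 nM to 25000 nM.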

Compound 4, half-maximal inhibitory concentration: > 20000 nM
Compound 4 gave a limit, no number; the forecaster's own chance of this, stated with the estimate: 5%; middle value at least 2.0-fold (0.30 log units) away from the limit.
By their numbers in this assay, from the lowest: compounds 3, 1 and 2 (each within the scatter of the next). At a limit, above all of these: compound 4.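

In this assay compound 4 gives > 20000 nM as a limit of the assay and not a number: the limit of > 20000 nM in this assay, at which 1 of the 4 values shown sits. The steps to it read an at least 1.4-fold higher number from compound 2 to compound 4 (0.16 log units; that floor lies within the scatter), an at least 1.8-fold higher number from compound 1 to compound 4 (0.25 log units; that floor lies within the scatter) and an at least 2.0-fold higher number from compound 3 to compound 4 (0.30 log units; that floor lies within the scatter), so each floor still lies within the scatter and no loss of activity beyond the scatter is established. Among the compounds shown here, what is new at this aromatic carbon, para to a large group, is that the exchange of bromo for chloro left a measured number, whereas hydroxy, which carries a hydrogen-bond donor and a hydrogen-bond acceptor where bromo has neither, gives only a limit, and this is the first sign that the position may not be indifferent to every replacement.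

From the compounds shown here alone, how far compound 4 really lies from the halogen compounds stays open, as does whether that distance would exceed the scatter. Also open, going by these compounds, is whether an amine or a carboxylic acid at this same carbon would stay with the halogen compounds or go the way of compound 4.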